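This account rests on a few compounds, and the source may have more. Where it says the series, first, only, none or still open, it means among the compounds named here.

Measured so far in a functional assay on MDA-MB-231 cells (Homo sapiens) for antiproliferative activity, read by MTT assay, with a stated time of 72 h; a higher number here means a weaker inhibitor, a lower number a stronger inhibitor:

compound 1 `CC1=CC[C@H]2[C@@H]1CC=C(C)[C@@H](CCC1=C(C)CC[C@@H]3OC(C)(C)[C@@H](O)CC[C@@]13C)C2(C)C`: > 50000 nM.
compound 2 `CC(=O)O[C@H]1CC[C@]2(C)[C@H](CC[C@@](C)(O)[C@H]2CC[C@@H]2C(C)=CC[C@H]3[C@H](CC[C@]3(C)OC(C)=O)C2(C)C)OC1(C)C`: 26200 nM.
compound 3 `CC1=CC[C@H]2[C@H](CC[C@]2(C)O)C(C)(C)[C@@H]1CC[C@H]1[C@]2(C)CC[C@H](OC(=O)c3ccc(F)cc3)C(C)(C)O[C@H]2CC[C@@]1(C)O`: 11300 nM.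

For compound 1 the entry is a limit of this assay rather than a number, namely (the limit of > 50000 nM in this assay, at which 1 of the 3 values shown sits). Of the two numbers given, compound 3 has the lowest, and compound 2 sits in the higher direction by a gap that is beyond the usual scatter of repeated measurements.

Compound 4 `CC1=CC[C@H]2[C@H](CC[C@]2(C)O)C(C)(C)[C@@H]1CC[C@H]1[C@]2(C)CC[C@H](OC(=O)c3ccco3)C(C)(C)O[C@H]2CC[C@@]1(C)O` differs from compound 3 by a single exchange: furan-2-yl in place of 4-fluorophenyl on a carbonyl carbon. The exchange sits on a carbonyl carbon whose other neighbour is an oxygen next to a carbonyl group, so the shared core is untouched. Among the compounds with values here, no pair of measured compounds shows what such an exchange does in this assay, and the two aromatic groups are of similar size, one carrying a hydrogen-bond acceptor that the other lacks. The expected step of a 1.1-fold higher number from compound 3 to compound 4 (0.03 log units; within the scatter) is small, in no firm direction, and likely within the scatter. Compound 4 is estimated at 12000 nM, with a range from 5000 nM to 30000 nM.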

Compound 4, half-maximal inhibitory concentration: 14000 nM
Estimate against measurement, compound 4: 1.2-fold (0.07 log units) below; the measured number falls inside the stated range.
By their numbers in this assay, from the lowest: compounds 3, 4 and 2 (each within the scatter of the next, the first and the last beyond it). At a limit, above all of these: compound 1.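

In this assay, the exchange of 4-fluorophenyl for furan-2-yl on a carbonyl carbon gives a 1.2-fold higher number from compound 3 to compound 4 (0.09 log units; within the scatter) within the scatter of repeated measurements. Within the data shown here, this is the first measured pair that differs in one place, and it shows that this position accepts either a six-membered aromatic ring of carbon only or a five-membered aromatic ring with 1 hetero atom without a readable difference. The hydrogen-bond acceptor counted on furan-2-yl, absent from 4-fluorophenyl, comes with no step beyond the scatter.

Going by these compounds, whether a saturated carbon chain or a ring carrying an amine at this same place would move the number beyond the scatter stays open. Nothing measured among these compounds accounts for how close the two numbers lie.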